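A few compounds are considered here, and "the series" means these few. Any claim that something is new, unique, unknown or untested is made for them only; others in the source may bear on it.

Of the compounds shown here, two built on a shared core have so far been tested in a functional assay on PC-3 cells (Homo sapiens) for inhibition, read by sulforhodamine B assay, with a stated time of 48 h; on this read-out lower numbers stand for stronger inhibition of growth and higher numbers for weaker inhibition of growth. In this test, compound 1 (`CC1(/C=C/c2ccc(C(F)(F)F)cc2)C=CC(=O)O1`) gives 13100 nM, while compound 2 (`COc1ccc(/C=C/C2(C)C=CC(=O)O2)c(OC)c1`) gives 63500 nM. Compound 2 therefore holds the higher of the two numbers, making it the weaker growth inhibitor of the pair, and the gap between them lies beyond the usual scatter of repeated measurements.

Compound 3 (`COc1ccc(/C=C/C2(C)C=CC(=O)O2)cc1`) has not yet been measured in this assay. It differs from compound 2 in a single place: hydrogen in place of methoxy on an aromatic carbon. In words, this is hydrogen in place of methoxy on an aromatic carbon. Among the measured compounds shown here, no two measured compounds differ in just one place, so the data give no direct guide to the size of this step. The only other reference point is compound 1 at 13100 nM, so a modest move towards a lower number is expected, possibly not much beyond the scatter. The expected change is a 1.7-fold lower number from compound 2 to compound 3 (0.22 log units; within the scatter). The estimated value for compound 3 is 38000 nM, with an expected range from 15000 nM to 85000 nM.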

Compound 3, concentration for total growth inhibition: 145000 nM
For compound 3 the middle estimate is 3.8-fold (0.58 log units) below the measured one; measured number above the stated range.
By their numbers in this assay, from the lowest: compound 1; then compound 2; then compound 3.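

Taking away the methoxy group that sits ortho to the group of 9 heavy atoms weakens growth inhibition in this assay, with a 2.3-fold higher number from compound 2 to compound 3 (0.36 log units; beyond the scatter), so this methoxy on an aromatic carbon contributes to the activity of compound 2, although the step is modest. Swapping trifluoromethyl on an aromatic carbon for methoxy is a large step, with an 11-fold higher number from compound 1 to compound 3 (1.04 log units; beyond the scatter), which makes the choice of this group weigh more in this small set than the presence of the second methoxy. Nothing measured alongside these compounds accounts for either step.

From the compounds shown here alone, at the carbon that lost its methoxy, only methoxy and hydrogen can be compared, so it remains open whether a hydroxyl group, a fluorine atom or a longer chain such as ethoxy would give a lower or a higher number there. Going by these compounds, it also remains open whether an amine or a nitrile could match trifluoromethyl on its aromatic carbon, and whether adding a second methoxy group to compound 1 would strengthen growth inhibition as it does in going from compound 3 to compound 2.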